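The source may report more compounds than this note shows. Statements on the series, on what has been measured and on what is new or still open speak of the compounds shown alone.

Measured in a functional assay on M21 cells (Homo sapiens) for antiproliferative activity, read by sulforhodamine B assay, with a stated time of 48 h; a lower number here means a stronger inhibitor, a higher number a weaker inhibitor:
compound 1 `COc1ccccc1OS(=O)(=O)c1ccc(N2CCN(C)C2=O)cc1`: 21000 nM
compound 2 `CCN1CCN(c2ccc(S(=O)(=O)Oc3ccccc3OC)cc2)C1=O`: > 100000 nM (a limit)
compound 3 `CCCN1CCN(c2ccc(S(=O)(=O)Oc3ccccc3OC)cc2)C1=O`: > 100000 nM (a limit)

Compound 3 has no number and stands at > 100000 nM, which is a limit of the assay. Its neighbours share this position: the limit of > 100000 nM in this assay, at which 2 of the 3 values shown sit. Compound 4 `CCCN1CCN(c2ccc(S(=O)(=O)Oc3cccc(C)c3)cc2)C1=O` keeps the chain of compound 3 and changes one place: 3-methylphenyl in place of 2-methoxyphenyl on an oxygen, (3-methylphenyl in place of 2-methoxyphenyl on an oxygen).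

The measured steps all lie in the chain on the amide-type nitrogen in a ring. They are an at least 4.7-fold higher number from compound 1 to compound 2 (0.67 log units; beyond the scatter) and an at least 4.7-fold higher number from compound 1 to compound 3 (0.67 log units; beyond the scatter), while a step that the two limits leave unreadable from compound 2 to compound 3 gives no size. None of them touches the group on the oxygen, so the series offers no direct measure for this swap. Going by the values given here, the only readable anchor is compound 1 at 21000 nM. In this assay a lower number is therefore expected only tentatively, and compound 4 may well stay at the limit. The expected step is an at least 2.5-fold lower number from compound 3 to compound 4 (0.39 log units; beyond the scatter). Compound 4 is estimated at 40000 nM, with an expected range of 5000 nM to 100000 nM.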

Compound 4, half-maximal inhibitory concentration: 28000 nM
For compound 4 the middle estimate is 1.4-fold (0.15 log units) above the measured one; low and high end bracket the measured number.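

Going by these compounds alone, the group on the oxygen is the first position to give a readable step away from the limit: in this assay, 3-methylphenyl in place of 2-methoxyphenyl gives an at least 3.5-fold lower number from compound 3 to compound 4 (0.55 log units; beyond the scatter). The chain of compound 3 therefore does not by itself hold a compound at the limit, where compound 2 and compound 3 remain: the limit of > 100000 nM in this assay, at which 2 of the 4 values shown sit. The swap replaces one substituent with another and also changes its printed ring position, so the step cannot be assigned to either change alone.

The step from compound 2 to compound 3 cannot be read, which leaves the effect of chain length at the limit unresolved. Also open, going by these compounds, are how 3-methylphenyl behaves with the chain of compound 1 and how an amine or a carboxylic acid on the phenyl group would read.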